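From Hydroxy to Methoxy on an Aromatic Ring

The source may hold more compounds than are shown below. What is called first, only, known or untested is meant among the compounds shown, and "the series" means these compounds.

In a functional assay on A549 cells (Homo sapiens) for antiproliferative activity, read by sulforhodamine B assay, with a stated time of 48 h (a higher number here means a weaker inhibitor, a lower number a stronger inhibitor), compound 1 `O=C(NCCCNc1cc(-c2cn(-c3ccccc3)nc2-c2cccc(O)c2)ccn1)Nc1ccc(F)cc1` gives 3120 nM. Among the measured compounds shown here, its only measured neighbour, compound 2 `O=C(NCCCNc1cc(-c2cn(-c3ccccc3)nc2-c2cccc(O)c2)ccn1)Nc1cccc(C(F)(F)F)c1`, gives 3350 nM. These two values lie within the scatter of each other, so neither compound can be ranked above the other.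

The next molecule, compound 3 `COc1cccc(-c2nn(-c3ccccc3)cc2-c2ccnc(NCCCNC(=O)Nc3ccc(F)cc3)c2)c1`, has not been measured. It differs from compound 1 by methyl in place of hydrogen on an oxygen on an aromatic ring, which turns 3-hydroxyphenyl into 3-methoxyphenyl.

For the measured compounds named here, the one measured step, a 1.1-fold higher number from compound 1 to compound 2 (0.03 log units; within the scatter), put 3-(trifluoromethyl)phenyl in place of 4-fluorophenyl on an amide-type nitrogen. That step stayed within the scatter, but it concerns a different part of the molecule and bears only loosely on the oxygen. Going by the values given here, no measured compound tests a change at that oxygen, so the data give no direction, and no step beyond the scatter is expected in this assay. The expected step is a 1.1-fold higher number from compound 1 to compound 3 (0.05 log units; within the scatter). The estimate for compound 3 is 3500 nM, with an expected range from 1200 nM to 10000 nM.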

Compound 3, half-maximal inhibitory concentration: 9950 nM
Compound 3: middle estimate off by 2.8-fold (0.45 log units), on the low side; low and high end bracket the measured number.
By their numbers in this assay, from the lowest: compounds 1 and 2 (each within the scatter of the next); then compound 3.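

In this assay this is the first change among the compounds shown that moves the number beyond the scatter, giving a 3.2-fold higher number from compound 1 to compound 3 (0.50 log units; beyond the scatter) as a modest step. The other measured change, on the amide-type nitrogen, gave only a 1.1-fold higher number from compound 1 to compound 2 (0.03 log units; within the scatter) and so left the two compounds unranked. A single methyl on the oxygen of the 3-hydroxyphenyl group therefore matters more in this small set, and here 3-methoxyphenyl goes with a weaker inhibitor than 3-hydroxyphenyl, although no measurement shown explains the shift.

This one pair cannot say whether the higher number comes from losing the hydrogen on the oxygen or from adding the methyl, and an ethoxy group, an amino group or a fluorine in place of the hydroxy would help to separate those two readings. Also open, going by these compounds, is whether the same methyl change would give a step of similar size on compound 2, which carries 3-(trifluoromethyl)phenyl at the other end of the molecule.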